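Two Carboxylic Acid Chains Compared Across Two Cores

This account rests on a few compounds, and the source may have more. Where it says the series, first, only, none or still open, it means among the compounds named here.

Measured compounds:
Compound 1, `CC(CC(=O)O)N1Cc2ccc(NC(=O)c3ccc(C4CCNCC4)cc3)cc2C1=O`: 6200 nM
Compound 2, `CC(CC(=O)O)N1Cc2ccc(NC(=O)c3ccc4c(c3)CNCC4)cc2C1=O`: 86 nM
Compound 3, `O=C(O)CCCN1Cc2ccc(NC(=O)c3ccc(C4CCNCC4)cc3)cc2C1=O`: 410000 nM

Three compounds were tested in a functional assay on a cell-free system (Platelet, plasma, Homo sapiens) for inhibition; on this read-out lower numbers stand for stronger inhibition and higher numbers for weaker inhibition. In this assay compound 1 gives 6200 nM, and compound 3 gives 410000 nM. The two differ in one place: 3-carboxypropyl in place of 1-(carboxymethyl)ethyl on an amide-type nitrogen in a ring. That change gives a 66-fold higher number from compound 1 to compound 3 (1.82 log units; beyond the scatter). Compound 2, which gives 86 nM in this assay, has the lowest number of the three; its structure and that of compound 1 differ in their cores, and the difference between the two cores is not broken down here.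

Compound 4, `O=C(O)CCCN1Cc2ccc(NC(=O)c3ccc4c(c3)CNCC4)cc2C1=O`, has not yet been measured in this assay. It is related to compound 2 by the same change that relates compound 1 to compound 3: 3-carboxypropyl in place of 1-(carboxymethyl)ethyl on an amide-type nitrogen in a ring. Among the compounds shown this change occurs twice in all.

Because the change from compound 1 to compound 3 produced a 66-fold higher number from compound 1 to compound 3 (1.82 log units; beyond the scatter), a step of similar size is expected from compound 2 to compound 4, namely a 58-fold higher number from compound 2 to compound 4 (1.76 log units; beyond the scatter). That expectation rests on a single measured pair and on compound 2 as the starting point, so it carries some uncertainty. For compound 4 in this assay the expected value is 5000 nM, with a range from 1500 nM to 25000 nM.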

Compound 4, half-maximal inhibitory concentration: 330000 nM
Compound 4: middle estimate off by 66-fold (1.82 log units), on the low side, outside the stated range (above it).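

In this assay the exchange of 1-(carboxymethyl)ethyl for 3-carboxypropyl on the amide-type nitrogen raises the number on the second core as well, giving a 3800-fold higher number from compound 2 to compound 4 (3.58 log units; beyond the scatter). Set beside the earlier step, the direction of the change carries over from one core to the other, but its size does not: the same change on two cores in this assay, a 66-fold higher number (1.82 log units; beyond the scatter) from compound 1 to compound 3 and a 3800-fold higher number (3.58 log units; beyond the scatter) from compound 2 to compound 4, 58-fold (1.76 log units) apart, beyond the scatter of two such steps. Among these compounds, the pair therefore shows that, in this series, the size of the step measured on one core cannot simply be transferred to the other; it does not show why the two steps differ, and with only two pairs it says nothing about how the change would behave on any further core, although with the 3-carboxypropyl chain compound 3 gives 410000 nM and compound 4 gives 330000 nM.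

The compounds shown leave open how a shorter or a longer chain ending in a carboxylic acid would behave on either core, and so whether the steps follow the length of the chain or the branch in 1-(carboxymethyl)ethyl. On these data alone, it also remains open how each of the two mirror-image forms of that branched chain would compare, and whether an ester or a primary amide in place of the carboxylic acid would keep the same difference between the cores.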